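Triazole-to-tetrazole swap on the thioether of compound 2

This account rests on a few compounds, and the source may have more. Where it says the series, first, only, none or still open, it means among the compounds named here.

Measured so far:
compound 1 `Cn1nnnc1SCC(=O)N/N=c1/scc(-c2ccc([N+](=O)[O-])cc2)n1-c1ccccc1` gives 58.6%
compound 2 `Cn1cnnc1SCC(=O)N/N=c1/scc(-c2ccccc2)n1-c1ccccc1` gives 35.5%

In a functional assay on C6 cells (Rattus norvegicus) for cytotoxicity, read by MTT assay, with a stated time of 24 h, tested at 200 ug/mL (a higher number here means a weaker effect of the compound at the concentration tested, a lower number a stronger effect), compound 2 stands lowest of the two numbers; compound 1 sits a number higher, and that gap is beyond the scatter. Compound 3 `Cn1nnnc1SCC(=O)N/N=c1/scc(-c2ccccc2)n1-c1ccccc1` is not yet measured. It differs from compound 2 in one place: 1-methyl-1H-tetrazol-5-yl in place of 4-methyl-4H-1,2,4-triazol-3-yl on a sulfur. Among the measured compounds shown here, no measured pair isolates this change, so its size is unknown; compound 1 carries the entering group but also a different aryl. A modest rise toward compound 1 is expected, a number 10.5 percentage points higher from compound 2 to compound 3 (beyond the scatter), though a step within the scatter cannot be excluded. Compound 3 is estimated at 46%, between 32% and 60%.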

Compound 3, a percentage reported as activity, at one concentration (the size of the read-out at that concentration, not a potency): 26.8%
Compound 3: the middle estimate sits 19.2 percentage points above what was measured, and the stated range ends above it.
By their numbers in this assay, from the lowest: compounds 3 and 2 (each within the scatter of the next); then compound 1.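

In this assay, 1-methyl-1H-tetrazol-5-yl in place of 4-methyl-4H-1,2,4-triazol-3-yl on the sulfur gives a number 8.7 percentage points lower from compound 2 to compound 3 (within the scatter), so at this position the swap stays inside the scatter. With the 1-methyl-1H-tetrazol-5-yl group held fixed, hydrogen in place of nitro on an aromatic carbon gives a number 31.8 percentage points lower from compound 1 to compound 3 (beyond the scatter), a large step. Of the two single changes, only the nitro-to-hydrogen change moves the read-out beyond the scatter.

Open, from the compounds shown here alone, is how an amine or a carboxylic acid in place of nitro on that aromatic carbon would read. No data at hand bear on the cause of either step.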